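Cytotoxicity notes on biaryl-substituted anilinopyrimidine series

A few compounds are considered here, and "the series" means these few. Any claim that something is new, unique, unknown or untested is made for them only; others in the source may bear on it.

Measured so far in an ADME assay on MT4 cells (Homo sapiens) for cytotoxicity, read by MTT assay, with a stated time of 4 days; on this read-out lower numbers stand for higher toxicity in this test and higher numbers for lower toxicity in this test:
compound 1 `Cc1cc(-c2ccc(Cl)cc2)cc(C)c1Nc1ccnc(Nc2ccc(C#N)cc2)n1` gives 4190 nM
compound 2 `Cc1cc(-c2cccc(F)c2)cc(C)c1Nc1ccnc(Nc2ccc(C#N)cc2)n1` gives 4120 nM
compound 3 `Cc1cc(-c2cccc(Cl)c2)cc(C)c1Nc1ccnc(Nc2ccc(C#N)cc2)n1` gives 2160 nM

All three numbers lie close together. Compound 3 sits with the other two inside the usual scatter of this read-out: a 1.9-fold lower number from compound 2 to compound 3 (0.28 log units; within the scatter) and a 1.9-fold lower number from compound 1 to compound 3 (0.29 log units; within the scatter). The remaining comparison, a 1.0-fold lower number from compound 1 to compound 2 (0.01 log units; within the scatter), is flat as well, so moving the halogen around the pendant phenyl ring, or swapping chloro for fluoro, has so far produced nothing that can be told apart from repeat measurement.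

Compound 4 `Cc1cc(-c2ccccc2F)cc(C)c1Nc1ccnc(Nc2ccc(C#N)cc2)n1` is not yet measured. Its change from compound 3 is 2-fluorophenyl in place of 3-chlorophenyl on an aromatic carbon. Two of the measured steps bear on it: the halogen swap in a 1.9-fold lower number from compound 2 to compound 3 (0.28 log units; within the scatter) and the change of substitution pattern in a 1.0-fold lower number from compound 1 to compound 2 (0.01 log units; within the scatter), both within scatter. Compound 4 combines a fluoro for chloro exchange with yet another ring position, but nothing measured suggests that either kind of change moves this assay. For compound 4 the expectation is therefore no step beyond the scatter, a 1.4-fold higher number from compound 3 to compound 4 (0.14 log units; within the scatter), and an estimated value of 3000 nM in this assay, with a range from 1200 nM to 8000 nM.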

Compound 4, half-maximal cytotoxic concentration: 2120 nM
Compound 4: middle estimate off by 1.4-fold (0.15 log units), on the high side; the range from low to high includes it.
By their numbers in this assay, from the lowest: compounds 4, 3, 2 and 1 (each within the scatter of the next).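

In this assay, the 2-fluorophenyl group extends the comparison to a further halogen placement on the pendant ring, and exchanging 3-chlorophenyl for it gives a 1.0-fold lower number from compound 3 to compound 4 (0.01 log units; within the scatter), so changing the halogen and its ring position in one step still produces no separable effect. With fluoro kept and only its ring position changed, the result is a 1.9-fold lower number from compound 2 to compound 4 (0.29 log units; within the scatter), while changing both the halogen and its ring position from the 4-chlorophenyl compound gives a 2.0-fold lower number from compound 1 to compound 4 (0.30 log units; within the scatter), so all four compounds now remain within the scatter across these halogen and placement changes. The data available here offer no explanation for this flat picture.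

Going by these compounds, all four compounds carry a single halogen on the pendant phenyl ring, so the response of this read-out to a non-halogen substituent there, such as an amine, a carboxylic acid or a longer alkyl chain, remains open. Also open, on these data alone, is whether replacing the pendant phenyl with a group such as morpholine, or replacing the nitrile with a carboxylic acid, would give a step beyond the scatter.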